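Changing the Group on the Ring Amine Nitrogen

The source may hold more compounds than are shown below. What is called first, only, known or untested is meant among the compounds shown, and "the series" means these compounds.

Compound 1 `CCCn1c(=O)[nH]c2nc(-c3ccc(S(=O)(=O)N4CCN(c5ccc(Cl)cc5F)CC4)cc3)[nH]c2c1=O` gives 14% in an assay on CHO cells for displacement of a labelled ligand from adenosine receptor A3 (Homo sapiens), read by scintillation counting, with a stated time of 45 min, tested at 1 uM, in the presence of a further agent that is not named here; on this read-out lower numbers stand for less inhibition and higher numbers for more inhibition at the one concentration tested (going by the name of the read-out).
Compound 2 `CCCn1c(=O)[nH]c2nc(-c3ccc(S(=O)(=O)N4CCN(Cc5cccc(C)c5)CC4)cc3)[nH]c2c1=O` gives 17% in this assay.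
Compound 3 `CCCn1c(=O)[nH]c2nc(-c3ccc(S(=O)(=O)N4CCN(c5ccc(C)cc5)CC4)cc3)[nH]c2c1=O` gives 25% in this assay.

Compound 1 stands lowest of the three numbers. Its nearest neighbour is compound 2, reached by a number 3 percentage points higher from compound 1 to compound 2 (within the scatter), which stays within the scatter; its furthest is compound 3, reached by a number 11 percentage points higher from compound 1 to compound 3 (beyond the scatter), a modest rise beyond the scatter. The gap between compound 2 and compound 3, a number 8 percentage points higher from compound 2 to compound 3 (within the scatter), is within the scatter.

Compound 4 `CCCn1c(=O)[nH]c2nc(-c3ccc(S(=O)(=O)N4CCN(c5cccc(F)c5)CC4)cc3)[nH]c2c1=O` differs from compound 1 by 3-fluorophenyl in place of 4-chloro-2-fluorophenyl on an amine nitrogen in a ring. Both measured steps from compound 1 bear on this, as each also exchanges the 4-chloro-2-fluorophenyl group on the amine nitrogen in the ring; one gave no change beyond the scatter, the other a modest rise. Compound 4 is therefore expected to sit near or slightly above compound 1 in this assay, with a step of about a number 6 percentage points higher from compound 1 to compound 4 (within the scatter) that may not exceed the scatter. Compound 4 is estimated at 20%, expected between 8% and 32%.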

Compound 4, a percentage reported as inhibition, at one concentration (the size of the read-out at that concentration, not a potency): 44%
Compound 4: the middle estimate sits 24 percentage points below what was measured; the whole stated range lies below it.
By their numbers in this assay, from the lowest: compounds 1, 2 and 3 (each within the scatter of the next, the first and the last beyond it); then compound 4.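

In this assay compound 4 stands clear of all three earlier compounds, with a number 30 percentage points higher from compound 1 to compound 4 (beyond the scatter) and a number 19 percentage points higher from compound 3 to compound 4 (beyond the scatter) and also a number 27 percentage points higher from compound 2 to compound 4 (beyond the scatter). Among these compounds, the earlier groups on this amine nitrogen gave numbers each within the scatter of the next, whereas 3-fluorophenyl is the first group to separate from all of them. Compound 1 and compound 4 both carry a fluorine on the phenyl ring, so fluorine on that ring does not by itself set the number here, and nothing available explains the rise.

From the compounds shown here alone, this exchange removes the chlorine and alters the fluorine's placement together, so the contribution of each remains open. Also open, going by these compounds, is how a plain phenyl, a 4-fluorophenyl or a 3-chlorophenyl on the same nitrogen would read in this assay.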